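Working notes on the step from compound 2 to compound 3

This account rests on a few compounds, and the source may have more. Where it says the series, first, only, none or still open, it means among the compounds named here.

Going by the values given here, in an ADME assay on the whole organism for inhibition, with Oryza sativa as the target, with a stated time of 4 days (a higher number here means a weaker inhibitor, a lower number a stronger inhibitor), compound 2 `CCCCNc1nc(Cl)nc(N[C@@H](C)c2ccccc2)n1` gives 23400 nM, the highest of the two numbers so far; compound 1 `CC[C@H](C)Nc1nc(Cl)nc(N[C@@H](C)c2ccccc2)n1` gives 6920 nM. Compound 3 `CCN(CC)c1nc(Cl)nc(N[C@@H](C)c2ccccc2)n1` differs from compound 2 by diethylamino in place of butylamino on an aromatic carbon. Among the compounds with values here, no measured pair carries this change. Within the data shown here, the only step that alters the same group, a 3.4-fold higher number from compound 1 to compound 2 (0.53 log units; beyond the scatter), shows that rejoining the same carbons moves the number modestly, toward a higher value. For compound 3 a step of comparable size toward a higher number is expected, a 1.7-fold higher number from compound 2 to compound 3 (0.23 log units; within the scatter), with wide uncertainty. Compound 3 is accordingly estimated at 40000 nM, range 12000 nM to 130000 nM.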

Compound 3, half-maximal inhibitory concentration: 380 nM
Compound 3: the middle estimate sits 110-fold (2.02 log units) above what was measured, and the stated range ends above it.
By their numbers in this assay, from the lowest: compound 3; then compound 1; then compound 2.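

In this assay, the position on the aromatic carbon proves far more sensitive to how the four carbons are arranged than the earlier pair showed: the change gives a 62-fold lower number from compound 2 to compound 3 (1.79 log units; beyond the scatter) and, against the branched amine, an 18-fold lower number from compound 1 to compound 3 (1.26 log units; beyond the scatter). Diethylamino, with 0 hydrogen-bond donors, gives the lowest number, while the two groups with 1 hydrogen-bond donor give higher numbers. No measured evidence bears on the cause of this shift.

Going by these compounds, whether the low number is specific to diethylamino or extends to dimethylamino or dipropylamino remains open. Also open, on these data alone, is whether a methyl group on the nitrogen of butylamino would give a similar step.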